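The source may report more compounds than this note shows. Statements on the series, on what has been measured and on what is new or still open speak of the compounds shown alone.

Series in a functional assay on KG-1 cells (Homo sapiens) for inhibition, read by MTT assay, with a stated time of 48 h; a higher number here means a weaker inhibitor, a lower number a stronger inhibitor:
- compound 1 `O=C(CCCCOC(=O)c1ccc2c(c1)no[n+]2[O-])NO`: 8190 nM
- compound 2 `O=C(CCCCCOC(=O)c1ccc2c(c1)no[n+]2[O-])NO`: 3690 nM
- compound 3 `O=C(CCCCCCOC(=O)c1ccc2c(c1)no[n+]2[O-])NO`: 370 nM

Compound 3, at 370 nM, has the lowest number of the three, and its steps to both others lie beyond the scatter. The next member, compound 4 `O=C(CCCCCCCOC(=O)c1ccc2c(c1)no[n+]2[O-])NO`, has not yet been measured in this assay. The change is (hydroxycarbamoyl)methyl in place of hydroxycarbamoyl on a saturated chain carbon, six bonds along the chain from an oxygen next to a carbonyl group: (hydroxycarbamoyl)methyl in place of hydroxycarbamoyl, six bonds along the chain from an oxygen next to a carbonyl group.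

The same replacement has been measured twice, closer along the chain. The first case is a 2.2-fold lower number from compound 1 to compound 2 (0.35 log units; beyond the scatter), and the second is a 10-fold lower number from compound 2 to compound 3 (1.00 log units; beyond the scatter). Both moved to a lower number, and the two combined give a 22-fold lower number from compound 1 to compound 3 (1.35 log units; beyond the scatter). Among the measured compounds shown here, no measured compound goes against this trend, but it rests on three compounds only, and nothing yet shows where it ends. A further move to a lower number is therefore expected, with the smaller of the two steps as the guide rather than the larger. The expected change is a 2.3-fold lower number from compound 3 to compound 4 (0.36 log units; beyond the scatter). Compound 4 is estimated at 160 nM, with an expected range of 40 nM to 700 nM. The upper end of that estimate leaves room for a reversal of the trend.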

Compound 4, half-maximal inhibitory concentration: 5210 nM
Beside the measured number, compound 4's estimate is 33-fold (1.51 log units) below it; measured number above the stated range.
By their numbers in this assay, from the lowest: compound 3; then compounds 2, 4 and 1 (each within the scatter of the next, the first and the last beyond it).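

In this assay, (hydroxycarbamoyl)methyl in place of hydroxycarbamoyl, six bonds along the chain from an oxygen next to a carbonyl group, gives a 14-fold higher number from compound 3 to compound 4 (1.15 log units; beyond the scatter), so the direction of this one change depends on where along the chain it is made: the same change on two cores in this assay, a 2.2-fold lower number (0.35 log units; beyond the scatter) from compound 1 to compound 2 and a 14-fold higher number (1.15 log units; beyond the scatter) from compound 3 to compound 4, 31-fold (1.49 log units) apart, beyond the scatter of two such steps. Among the compounds shown here, the trend to lower numbers with chain growth therefore holds only as far as compound 3, compound 4 goes against it, and compound 3 is the only member whose steps to all three others lie beyond the scatter, which makes it a narrow optimum rather than the start of a plateau. The longer replacements show the same loss, with a 1.4-fold higher number from compound 2 to compound 4 (0.15 log units; within the scatter) and a 1.6-fold lower number from compound 1 to compound 4 (0.20 log units; within the scatter), both within the scatter, so none of the gain seen at compound 3 survives in compound 4: the same change on two cores in this assay, a 22-fold lower number (1.35 log units; beyond the scatter) from compound 1 to compound 3 and a 1.4-fold higher number (0.15 log units; within the scatter) from compound 2 to compound 4, 31-fold (1.49 log units) apart, beyond the scatter of two such steps.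

Going by these compounds, whether a chain longer than that of compound 4 stays at this level or moves again remains open. Also open, on these data alone, is whether an amide in place of the ester would keep the same sharp dependence on chain length.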